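The compounds below may be only part of what the source reports. "The series", "measured", "known", "first", "only" and "open" are said of these compounds alone.

The assay here is an ADME assay on HS27 cells (Homo sapiens) for antiproliferative activity, read by MTT assay, with a stated time of 24 h; on this read-out lower numbers stand for stronger inhibition and higher numbers for weaker inhibition. Two compounds have numbers in it. Compound 1 `O=C(Nc1ccc(-n2ccc3c(NC(=O)c4ccccc4)ncnc32)cc1)Nc1cccc(C(F)(F)F)c1` gives 4500 nM in this assay. Compound 2 `Nc1ncnc2c1ccn2-c1ccc(NC(=O)c2cccc(C(F)(F)F)c2)cc1` gives 7100 nM in this assay. Of these two numbers, that of compound 2 is the higher one, but its gap to compound 1 lies within the usual scatter, so the two compounds cannot be told apart on this evidence.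

Compound 3 `O=C(Nc1ccc(-n2ccc3c(NC(=O)c4ccccc4)ncnc32)cc1)c1cccc(C(F)(F)F)c1` has not yet been measured in this assay. It differs from compound 2 by benzoyl in place of hydrogen on a nitrogen on an aromatic ring. Going by the values given here, no pair of measured compounds shows the effect of this exact change, so there is nothing to read a direction from; the expected step from compound 2 to compound 3 in this assay is therefore estimated as a 1.3-fold lower number from compound 2 to compound 3 (0.11 log units; within the scatter), that is, no step beyond the scatter. Compound 3 is expected to give about 5500 nM, estimated to fall between 1800 nM and 17000 nM.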

Compound 3, half-maximal inhibitory concentration: 5900 nM
Estimate against measurement, compound 3: 1.1-fold (0.03 log units) below; the range from low to high includes it.
By their numbers in this assay, from the lowest: compounds 1, 3 and 2 (each within the scatter of the next).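

In this assay, benzoyl in place of hydrogen on a nitrogen on an aromatic ring gives a 1.2-fold lower number from compound 2 to compound 3 (0.08 log units; within the scatter), so this first reading of the amino to benzamido change shows no step beyond the scatter. The second new comparison, 3-(trifluoromethyl)phenyl in place of (3-(trifluoromethyl)phenyl)amino on a carbonyl carbon, gives a 1.3-fold higher number from compound 1 to compound 3 (0.12 log units; within the scatter), so this change also cannot be told apart from no change at all. No further data are available that bear on these two steps.

Still open, as far as these compounds go, is whether a smaller acyl group such as acetyl on that nitrogen would give a step beyond the scatter. Also open, from the compounds shown here alone, is whether an amine or a carboxylic acid in place of the trifluoromethyl group would do so.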